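Replacing 3,5-difluorophenyl with 2-hydroxyethyl in compound 3

The source may report more compounds than this note shows. Statements on the series, on what has been measured and on what is new or still open speak of the compounds shown alone.

In a functional assay on HeLa cells (Homo sapiens) for antiproliferative activity, read by MTT assay, with a stated time of 72 h (on this read-out lower numbers stand for stronger inhibition and higher numbers for weaker inhibition), compound 3 `O=C1O[C@H]([C@@H](O)Cn2cc(-c3cc(F)cc(F)c3)nn2)C(OCc2ccccc2)=C1OCc1ccccc1` gives 40800 nM and compound 2 `Cc1ccc(-c2cn(C[C@H](O)[C@H]3OC(=O)C(OCc4ccccc4)=C3OCc3ccccc3)nn2)cc1` gives 25500 nM, a pair that stands level: a 1.6-fold higher number from compound 2 to compound 3 (0.20 log units; within the scatter). Compound 1 `COc1ccccc1-c1cn(C[C@H](O)[C@H]2OC(=O)C(OCc3ccccc3)=C2OCc2ccccc2)nn1` gives only a limit, > 100000 nM.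

Compound 4 `O=C1O[C@H]([C@@H](O)Cn2cc(CCO)nn2)C(OCc2ccccc2)=C1OCc1ccccc1` differs from compound 3 in one place: 2-hydroxyethyl in place of 3,5-difluorophenyl on an aromatic carbon. Here 2-hydroxyethyl stands in place of 3,5-difluorophenyl on an aromatic carbon.

The measured steps at this carbon only exchange one substituted phenyl for another: an at least 3.9-fold lower number from compound 1 to compound 2 (0.59 log units; beyond the scatter), and an at least 2.4-fold lower number from compound 1 to compound 3 (0.38 log units; beyond the scatter). Both are at least modest and both start from a limit. None of them removes the aromatic ring, so they bear on this change only loosely. Compound 1 at > 100000 nM does show that a change at this carbon alone can leave the read-out at a limit. A modest step towards a higher number in this assay is therefore expected, and a limit result is a real possibility.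

The estimated step is a 2.2-fold higher number from compound 3 to compound 4 (0.34 log units; beyond the scatter). For compound 4 the expected value is 90000 nM, with an estimated range of 30000 nM to 250000 nM.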

Compound 4, half-maximal inhibitory concentration: 68800 nM
The estimate for compound 4 lay 1.3-fold (0.12 log units) above the measured number; measured number inside the range.
By their numbers in this assay, from the lowest: compounds 2, 3 and 4 (each within the scatter of the next, the first and the last beyond it). At a limit, above all of these: compound 1.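

In this assay the aromatic ring on this carbon can go without the number reaching a limit: 2-hydroxyethyl in place of 3,5-difluorophenyl gives a 1.7-fold higher number from compound 3 to compound 4 (0.23 log units; within the scatter) and leaves that pair level, while the same group in place of 4-methylphenyl gives a 2.7-fold higher number from compound 2 to compound 4 (0.43 log units; beyond the scatter) as a modest step. Within the data shown here, the exchange for 2-methoxyphenyl gives an at least 1.4-fold lower number from compound 1 to compound 4 (0.16 log units; that floor lies within the scatter) and fixes no order for that pair, its floor being all that can be read. Compound 1 remains a limit and not a number: the limit of > 100000 nM in this assay, at which 1 of the 4 values shown sits.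

Still open, going by these compounds, is whether an amine, a carboxylic acid or a longer chain on this carbon would move the number beyond the scatter from compound 4 in either direction. Also open, on these data alone, is where an unsubstituted phenyl would stand relative to compound 2 and compound 3.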